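Chloro in place of sulfamoyl on compound 2

The compounds below may be only part of what the source reports. "The series", "measured", "known", "first", "only" and "open" are said of these compounds alone.

compound 1 `CC(C)Oc1ccc(C(=O)Nc2ccc(N(C)C)cc2)cc1NC(=O)C(C)Br` gives 7900 nM
compound 2 `CN1CCN(Cc2ccc(NC(=O)c3ccc(OCCCCl)c(S(N)(=O)=O)c3)cc2C(F)(F)F)CC1` gives 5470 nM
compound 3 `COc1ccc(NC(=O)c2ccc(OCCCCl)c([N+](=O)[O-])c2)cc1` gives 39700 nM

In a toxicity assay on Huh-7.5 cells (Homo sapiens) for inhibition, read by MTT assay, with a stated time of 96 h (on this read-out lower numbers stand for higher toxicity in this test and higher numbers for lower toxicity in this test), compound 2 (5470 nM) lies within the scatter of compound 1 (7900 nM), and compound 3 (39700 nM) stands higher, by a gap beyond the scatter. Compound 2 therefore sits with compound 1 at the low end of this small set, though three compounds show no pattern.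

The next compound, compound 4 `CN1CCN(Cc2ccc(NC(=O)c3ccc(OCCCCl)c(Cl)c3)cc2C(F)(F)F)CC1`, keeps the whole of compound 2 except for one group. It has chloro in place of sulfamoyl on an aromatic carbon, ortho to a 3-chloropropoxy group chloro in place of sulfamoyl on an aromatic carbon and meta to a large group.

Within the data shown here, no two measured compounds differ in one place only, so the data hold no direct precedent for this change. The expectation therefore rests on compound 2 (5470 nM), whose remaining structure is carried over unchanged. In this assay no step beyond the scatter is expected, with only a slight lean towards a lower number, and that lean is a judgement and not a measured trend. The estimated step (a 1.4-fold lower number from compound 2 to compound 4 (0.14 log units; within the scatter)) is accordingly small. For compound 4 the expected value is about 4000 nM (estimated range 1500 nM to 11000 nM).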

Compound 4, half-maximal cytotoxic concentration: 4100 nM
Compound 4: middle estimate off by 1.0-fold (0.01 log units), on the low side, within the range that was stated.
By their numbers in this assay, from the lowest: compounds 4, 2 and 1 (each within the scatter of the next); then compound 3.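

In this assay, putting chloro in place of sulfamoyl on the aromatic carbon ortho to a 3-chloropropoxy group gives a 1.3-fold lower number from compound 2 to compound 4 (0.13 log units; within the scatter). Among these compounds, this is the first pair in the set to differ in one place, and it shows that the read-out does not separate the two compounds at this position, even though sulfamoyl brings a hydrogen-bond donor and acceptors and chloro brings neither. Nothing shown speaks to the reason for this result.

This single pair leaves open whether other groups on the same carbon, such as a nitrile, a methoxy group, a carboxylic acid or an amine, would also stay within the scatter of compound 2 and compound 4 in this assay. It also leaves open whether the exchange of sulfamoyl for chloro would give so small a step if the 3-chloropropoxy group were replaced by a longer chain or by a chain ending in an amine.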